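A few compounds are considered here, and "the series" means these few. Any claim that something is new, unique, unknown or untested is made for them only; others in the source may bear on it.

Compound 1, with the structure `CC(=O)OCCOn1cnc2c(Cl)nc(N)nc21`, was tested in a functional assay on HT-29 cells (Homo sapiens) for inhibition; a lower number here means a stronger inhibitor, a higher number a weaker inhibitor. In this assay compound 1 gives only a limit of the assay, > 500000 nM. Compound 2, with the structure `CC(=O)OCCOn1cnc2c(S)nc(N)nc21`, carries a sulfanyl group in place of the chloro group on an aromatic carbon. In this assay compound 2 also gives only a limit, > 500000 nM. The step that the two limits leave unreadable from compound 1 to compound 2 cannot be read, since both values sit at the same limit (the limit of > 500000 nM in this assay, at which 2 of the 2 values shown sit). Compound 3, with the structure `CC(=O)OCCOn1cnc2c(S)nc(F)nc21`, differs from compound 2 in one place: fluoro in place of amino on an aromatic carbon. No measured step bears on this change; the only step shown is unreadable. The expectation for compound 3 is therefore an unchanged outcome, a step of a number no higher from compound 2 to compound 3 (the limit leaves the size open) in this assay, most likely again reported as a limit. For compound 3 the estimated value is 500000 nM, within a range from 100000 nM to 2000000 nM.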

Compound 3, half-maximal inhibitory concentration: > 500000 nM
Compound 3 gave a limit, no number (the forecaster's own chance of this, stated with the estimate: 80%); the middle value sits exactly at the limit.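

No step from compound 2 to compound 3 can be read, because both compounds sit at the same limit and neither gives a number: the limit of > 500000 nM in this assay, at which 3 of the 3 values shown sit.

The compounds shown leave open how strongly any of them inhibits in this assay, and whether swapping chloro, sulfanyl, amino or fluoro changes that inhibition at all.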